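Side-chain branching in a pepsin inhibitor series

The source may hold more compounds than are shown below. What is called first, only, known or untested is meant among the compounds shown, and "the series" means these compounds.

Measured compounds:
compound 1 `CCCCCCC(O)[C@H](CCC)NC(=O)[C@@H](NC(=O)[C@@H](NC(=O)OC(C)(C)C)C(C)C)C(C)C` gives 700 nM in an assay on isolated protein for inhibition of Pepsin A (Homo sapiens); a higher number here means a weaker inhibitor, a lower number a stronger inhibitor
compound 2 `CCCCCCCCC(O)[C@H](CCC)NC(=O)[C@@H](NC(=O)[C@@H](NC(=O)OC(C)(C)C)C(C)C)C(C)C` gives 1070 nM in this assay

In this assay compound 2 and compound 1 sit within the scatter of each other, as a 1.5-fold higher number from compound 1 to compound 2 (0.18 log units; within the scatter) shows. Compound 3 `CCCCCCCCC(O)[C@@H](NC(=O)[C@@H](NC(=O)[C@@H](NC(=O)OC(C)(C)C)C(C)C)C(C)C)[C@@H](C)CC` differs from compound 2 by methyl in place of hydrogen on a saturated chain carbon bound to two saturated chain carbons; cut one bond further out this reads propyl to sec-butyl. Going by the values given here, no measured step touches this position; the only step known, a 1.5-fold higher number from compound 1 to compound 2 (0.18 log units; within the scatter), concerns a chain extension elsewhere and was within the scatter. Compound 3 is therefore expected to show a 1.1-fold lower number from compound 2 to compound 3 (0.03 log units; within the scatter), with an estimated value of 1000 nM in this assay, ranging from 400 nM to 2500 nM.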

Compound 3, half-maximal inhibitory concentration: 15000 nM
Estimate against measurement, compound 3: 15-fold (1.18 log units) below; the measured number lies above the stated range.
By their numbers in this assay, from the lowest: compounds 1 and 2 (each within the scatter of the next); then compound 3.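

Propyl to sec-butyl at this position is the first change in the series to go beyond the scatter: in this assay there is a 14-fold higher number from compound 2 to compound 3 (1.15 log units; beyond the scatter) for one added methyl on a saturated chain carbon bound to two saturated chain carbons. The number therefore responds to this position far more than to the chain extension elsewhere, where a 1.5-fold higher number from compound 1 to compound 2 (0.18 log units; within the scatter) stayed small. Nothing available bears on the reason for the size of this step.

On these data alone, whether an ethyl, isobutyl or benzyl group at this position would keep the number close to that of compound 2 remains open. Also open, as far as these compounds go, is whether sec-butyl has the same effect alongside the shorter chain of compound 1.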